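Oxazole series: alcohol analogue with carbamoyl replacing trifluoromethyl

This account rests on a few compounds, and the source may have more. Where it says the series, first, only, none or still open, it means among the compounds named here.

Of the compounds shown here, three have been measured in an assay (Rattus norvegicus) for inhibition of Fatty-acid amide hydrolase 1 (Homo sapiens); on this read-out lower numbers stand for stronger inhibition and higher numbers for weaker inhibition. Compound 1 `CC(=O)c1cnc(C(=O)CCCCCCc2ccccc2)o1` gives 2 nM; compound 2 `O=C(CCCCCCc1ccccc1)c1ncc(Cl)o1` gives 5 nM. Among the compounds with values here, the one step that can be read directly, chloro in place of acetyl on an aromatic carbon, is a 2.5-fold higher number from compound 1 to compound 2 (0.40 log units; beyond the scatter). Compound 3 `OC(CCCCCCc1ccccc1)c1ncc(C(F)(F)F)o1` gives 2300 nM, the highest of the three numbers; compound 2 stands nearest to it and compound 1 furthest, both of them far lower and well beyond the scatter. Compound 3 carries the alcohol rather than the ketone of compounds 1 and 2, together with trifluoromethyl, so the two changes cannot be separated on the numbers shown.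

Compound 4 `NC(=O)c1cnc(C(O)CCCCCCc2ccccc2)o1` keeps the alcohol of compound 3 and differs only in the group on the shared core: carbamoyl in place of trifluoromethyl on an aromatic carbon, placed on an aromatic carbon of the five-membered aromatic ring, next to the ring oxygen. Within the data shown here, no measured step varies this position within the alcohol compounds; the only comparison at this position is a 2.5-fold higher number from compound 1 to compound 2 (0.40 log units; beyond the scatter) among the ketones, which was modest. By that analogy the expected step in this assay is modest and toward a lower number, a 2.9-fold lower number from compound 3 to compound 4 (0.46 log units; beyond the scatter). Compound 4 is therefore estimated at 800 nM, with a range from 200 nM to 3000 nM.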

Compound 4, inhibition constant: 25000 nM
Estimate against measurement, compound 4: 31-fold (1.49 log units) below; the measured number lies above the stated range.
By their numbers in this assay, from the lowest: compound 1; then compound 2; then compound 3; then compound 4.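

In this assay, carbamoyl in place of trifluoromethyl on the aromatic carbon next to the ring oxygen gives an 11-fold higher number from compound 3 to compound 4 (1.04 log units; beyond the scatter), a large step and the first read directly among the alcohol compounds. Within the data shown here, the only earlier step at this position, a 2.5-fold higher number from compound 1 to compound 2 (0.40 log units; beyond the scatter), was modest and came from a different pair of groups among the ketones, so that step does not set the size of change possible here: this position can carry a large difference in inhibition, and with this pair of groups the alcohol series moves toward weaker inhibition. Nothing available explains the size or direction of this step.

Going by these compounds, the step from ketone to alcohol cannot be read with the same group on the shared core, so it remains open whether carbamoyl in place of trifluoromethyl would give a step of similar size in a ketone. Also open, on these data alone, is where a carboxylic acid, a nitrile or an amine at this position would fall relative to carbamoyl and trifluoromethyl on the alcohol core.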